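The source may report more compounds than this note shows. Statements on the series, on what has been measured and on what is new or still open speak of the compounds shown alone.

Compound 1 `N/N=C\c1cc(=O)oc2cc(OCc3ccccc3)cc(OCc3ccccc3)c12`: 363000 nM
Compound 2 `O=c1cc(/C=N\Nc2ccccc2)c2c(OCc3ccccc3)cc(OCc3ccccc3)cc2o1`: 40100 nM

These two compounds share one core and differ only in what sits on the amine nitrogen of the hydrazone arm. In a functional assay, read by spectrophotometry, with a stated time of 3 min (on this read-out lower numbers stand for stronger inhibition and higher numbers for weaker inhibition), compound 1 gives 363000 nM, while compound 2 gives 40100 nM. Among the measured compounds shown here, the single step measured so far, a 9.1-fold lower number from compound 1 to compound 2 (0.96 log units; beyond the scatter), shows that placing a phenyl on that nitrogen instead of hydrogen brings a clearly lower number. For the measured compounds named here, compound 2 therefore stands at the lower of the two numbers, with compound 1 its only neighbour and well beyond the scatter from it.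

Compound 3 `O=c1cc(/C=N\Nc2ccc([N+](=O)[O-])cc2[N+](=O)[O-])c2c(OCc3ccccc3)cc(OCc3ccccc3)cc2o1` has not yet been measured. Its change from compound 2 is 2,4-dinitrophenyl in place of phenyl on an amine nitrogen. Going by the values given here, the only measured step that bears on it is a 9.1-fold lower number from compound 1 to compound 2 (0.96 log units; beyond the scatter), which touches the same nitrogen but is a different exchange, so it serves only as a rough guide. In this assay compound 3 is expected to give 20000 nM, with a range of 5000 nM to 80000 nM. That estimate corresponds to an expected step of a 2.0-fold lower number from compound 2 to compound 3 (0.30 log units; within the scatter), a modest lowering that could also turn out to fall within the scatter.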

Compound 3, half-maximal inhibitory concentration: "not active" (no number reported)
Compound 3: no number reported, and the estimate cannot be compared.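

In this assay, among the compounds shown here, compound 3 is reported as "not active" with no number, so no step from compound 2 to compound 3 can be read. No measurement at hand explains this result. The compounds shown leave open how far 2,4-dinitrophenyl in place of phenyl on the amine nitrogen shifts the number.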